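The compounds below may be only part of what the source reports. "The series", "measured", "known", "first", "only" and "open" are said of these compounds alone.

Compound 1 `Cc1noc(C)c1-c1ccc2c(c1)c(Cc1ccccc1)cn2CCCCCC(=O)NO`: 15500 nM
Compound 2 `Cc1noc(C)c1-c1ccc2c(c1)c(CCc1ccccc1)cn2CCCCCC(=O)NO`: 15500 nM

In a functional assay on THP-1 cells (Homo sapiens) for inhibition (on this read-out lower numbers stand for stronger inhibition of growth and higher numbers for weaker inhibition of growth), compound 2 gives 15500 nM, level with compound 1 at 15500 nM. Compound 3 `Cc1noc(C)c1-c1ccc2c(c1)c(Cc1ccc(F)cc1)cn2CCCCCC(=O)NO` has not yet been measured. Its difference from compound 2 is 4-fluorophenyl in place of benzyl on a saturated chain carbon bound to an aromatic carbon. Going by the values given here, the only measured step at this place is no change at the digits printed from compound 1 to compound 2 (within the scatter). On that single step, no shift beyond the scatter is expected in this assay, in either direction. The estimated step is a 1.0-fold lower number from compound 2 to compound 3 (0.01 log units; within the scatter). For compound 3 the expected value is 15000 nM, with an estimated range of 7500 nM to 30000 nM.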

Compound 3, concentration for 50% growth inhibition: 15500 nM
Compound 3: the middle estimate sits 1.0-fold (0.01 log units) below what was measured; the range from low to high includes it.
By their numbers in this assay, from the lowest: compounds 1, 2 and 3 (each within the scatter of the next).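

In this assay, putting 4-fluorophenyl in place of benzyl on a saturated chain carbon bound to an aromatic carbon gives no change at the digits printed from compound 2 to compound 3 (within the scatter) and putting fluoro in place of hydrogen on an aromatic carbon gives no change at the digits printed from compound 1 to compound 3 (within the scatter). So the number at this position stays flat for a fluoro on the ring as well as for the one-carbon chain change seen earlier. No measurement here explains this flatness. From the compounds shown here alone, whether an amine or a carboxylic acid on that ring, or a longer chain carrying it, would shift the number remains open.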